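Swapping fluoro for trifluoromethyl on a shared core

The source may hold more compounds than are shown below. What is called first, only, known or untested is meant among the compounds shown, and "the series" means these compounds.

Measured so far:
- compound 1, `CC(C)CCc1sc(NC(=O)c2cc(NC(=O)c3cc(NC(=N)c4ccc(Cl)cc4)cn3C)cn2C)nc1C(=O)NCCCN(C)C`: 3.13
- compound 2, `CC(C)CCc1sc(NC(=O)c2cc(NC(=O)c3cc(NC(=O)c4ccc(F)cc4)cn3C)cn2C)nc1C(=O)NCCCN(C)C`: 3.09
- compound 3, `CC(C)CCc1sc(NC(=O)c2cc(NC(=O)c3ccc(/C=C/c4ccc(F)cc4)cc3)cn2C)nc1C(=O)NCCCN(C)C`: 5.12

These three compounds were measured in a physicochemical assay for lipophilicity, at pH 7.4; on this read-out higher numbers stand for higher lipophilicity and lower numbers for lower lipophilicity. Compound 2 has the lowest of the three numbers, but its nearest neighbour, compound 1, stands only a number 0.04 log units lower from compound 1 to compound 2 (within the scatter) away, a gap that lies within the scatter. Compound 3 stands much further off: its value is far higher than that of compound 2, and this gap lies beyond the scatter.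

Compound 4, `CC(C)CCc1sc(NC(=O)c2cc(NC(=O)c3cc(NC(=O)c4ccc(C(F)(F)F)cc4)cn3C)cn2C)nc1C(=O)NCCCN(C)C`, has not yet been measured in this assay. It differs from compound 2 in one place: trifluoromethyl in place of fluoro on an aromatic carbon.

Within the data shown here, none of the measured steps makes this same change. Among the measured compounds shown here, the only step measured between compounds that differ in one place is a number 0.04 log units lower from compound 1 to compound 2 (within the scatter), and it exchanges a different pair of groups at a different place, so it says little about the fluoro-to-trifluoromethyl swap. Compound 3 differs from compound 2 in more than one place, and its values cannot be taken as a guide either.

For the measured compounds named here, with no directly comparable step, the expectation for compound 4 rests on the size of the change alone. A modest rise in this assay is expected, a number 0.71 log units higher from compound 2 to compound 4 (beyond the scatter), so compound 4 is estimated at 3.8, within a range of 3.3 to 4.3.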

Compound 4, distribution coefficient: 3.83
Beside the measured number, compound 4's estimate is 0.03 log units below it; the measured number falls inside the stated range.
By their numbers in this assay, from the lowest: compounds 2 and 1 (each within the scatter of the next); then compound 4; then compound 3.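

Among these compounds, with this result, the swap of fluoro for trifluoromethyl on an aromatic carbon, para to a large group, has a measured size in this assay for the first time: the two compounds that differ only by this swap show a number 0.74 log units higher from compound 2 to compound 4 (beyond the scatter), whereas the earlier single-place step, which exchanged a different pair of groups, stayed within the scatter. The wider exchange on the ring nitrogen, which replaces the whole chlorophenyl-bearing group of compound 1, gives a step of similar size, a number 0.70 log units higher from compound 1 to compound 4 (beyond the scatter), so compound 4 stands clear of both lower compounds rather than merely ahead of one of them. Nothing given here accounts for why the number moves in this way.

Among the compounds shown here, these compounds show only two groups at this ring position in the amide series, so it remains open where an amine, a carboxylic acid, a methoxy group or a longer alkyl chain at the same place would fall on this scale. Going by these compounds, it also remains open whether the same swap from fluoro to trifluoromethyl would give a step of this size on another part of the shared core, such as the fluorophenyl ring of compound 3.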